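From 2-methylcyclohexyl to 4-methylcyclohexyl on the amide

The compounds below may be only part of what the source reports. "The series", "measured", "known", "first", "only" and "open" are said of these compounds alone.

Compound 1 `Cc1cc(C)c2cc(C(=O)NC3CCCCC3O)[nH]c2c1` gives 56000 nM
Compound 2 `C[C@H]1CCCC[C@H]1NC(=O)c1cc2c(Cl)cc(Cl)cc2[nH]1` gives < 4000 nM
Compound 3 `CC1CCC(NC(=O)c2cc3c(F)cc(F)cc3[nH]2)CC1` gives < 4000 nM

All three results come from a physicochemical assay for solubility, measured as thermodynamic solubility, with a stated time of 24 h, at pH 6.8 (a lower number here means a less soluble compound, a higher number a more soluble compound), and only one of them is a true number. Compound 1 gives 56000 nM as that number. Compound 2 gives < 4000 nM which is a limit of the assay and not a number. Its place on the scale is the limit of < 4000 nM in this assay, at which 2 of the 3 values shown sit, and no finer reading exists. Compound 3 gives < 4000 nM which is also a limit.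

Compound 4 `C[C@H]1CC[C@H](NC(=O)c2cc3c(Cl)cc(Cl)cc3[nH]2)CC1` has the same atoms as compound 2, joined differently (4-methylcyclohexyl in place of 2-methylcyclohexyl on an amide-type nitrogen) with 4-methylcyclohexyl in place of 2-methylcyclohexyl on an amide-type nitrogen. Going by the values given here, no pair of measured compounds shows this change on its own, so its size cannot be read from the data. No step beyond the usual scatter is expected, in either direction. Compound 3 also carries a 4-methylcyclohexyl group and gives < 4000 nM as a limit, so another result at that limit is the likeliest outcome. The expected change is a step that the limit leaves unreadable from compound 2 to compound 4 in this estimate. For compound 4 the estimated value is 3000 nM with an expected range of 1000 nM to 6000 nM around it.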

Compound 4, solubility: < 4000 nM
Compound 4: a limit, no number; the forecaster's own chance of this, stated with the estimate: 85%; the middle value is on the limit's open side.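

Compound 2 and compound 4 each give only a limit of the assay and not a number, so no step between them can be read: the limit of < 4000 nM in this assay, at which 3 of the 4 values shown sit.

Going by these compounds, how far the true values of compound 2 and compound 4 lie from that limit, and whether 4-methylcyclohexyl in place of 2-methylcyclohexyl changes the result at all, stays open.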